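The source may hold more compounds than are shown below. What is called first, only, known or untested is meant among the compounds shown, and "the series" means these compounds.

Compounds on a shared core have been read in a physicochemical assay for solubility, using the shake flask method, in simulated intestinal fluid, measured as kinetic solubility, with a stated time of 20 h, at pH 6.5; a lower number here means a less soluble compound, a higher number a more soluble compound. Compound 1 `Fc1ccc(-c2nc3cnc(Nc4ccc(C(F)(F)F)cn4)cc3[nH]2)cc1F` gives >= 50000 nM, which is a limit of the assay and not a number. In this assay compound 2 `FC1(F)CCC(c2nc3cnc(Nc4ccc(C(F)(F)F)cn4)cc3[nH]2)C1` gives 163000 nM, and compound 3 `FC(F)(F)c1ccc(Nc2cc3[nH]c(C4CCOC4)nc3cn2)nc1` gives 180000 nM, so compound 3 stands level with compound 2 within the scatter.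

Compound 4 `CC1(c2nc3cnc(Nc4ccc(C(F)(F)F)cn4)cc3[nH]2)CC1` carries 1-methylcyclopropyl in place of oxolan-3-yl on an aromatic carbon, between two ring nitrogen atoms: 1-methylcyclopropyl in place of oxolan-3-yl on an aromatic carbon.

Three measured steps changed this same place. Two give no size: a step that the limit leaves unreadable from compound 1 to compound 2, and a step that the limit leaves unreadable from compound 1 to compound 3. The only readable one is a 1.1-fold higher number from compound 2 to compound 3 (0.04 log units; within the scatter), where oxolan-3-yl replaced 3,3-difluorocyclopentyl. With that single step as a guide, no change beyond the scatter is expected in this assay, in either direction. The expected step is a 1.2-fold lower number from compound 3 to compound 4 (0.08 log units; within the scatter). The estimate for compound 4 is 150000 nM, with an expected range from 60000 nM to 300000 nM.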

Compound 4, solubility: 179000 nM
The estimate for compound 4 lay 1.2-fold (0.08 log units) below the measured number; the measured number falls inside the stated range.
By their numbers in this assay, from the lowest: compounds 2, 4 and 3 (each within the scatter of the next).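

In this assay, the oxygen of oxolan-3-yl and its hydrogen-bond acceptor can go, and a three-membered ring of carbon only can take the place of the five-membered ring, with no change beyond the scatter: a 1.0-fold lower number from compound 3 to compound 4 (0.00 log units; within the scatter). 1-Methylcyclopropyl also stands level with 3,3-difluorocyclopentyl, a 1.1-fold higher number from compound 2 to compound 4 (0.04 log units; within the scatter), so at this place, between two ring nitrogen atoms, the three non-aromatic rings shown give numbers within the scatter of one another, with or without oxygen or fluorine. Compound 1 gives a limit and not a number, and the steps from it, including the one to compound 4, cannot be read: the limit of >= 50000 nM in this assay, at which 1 of the 4 values shown sits.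

As far as these compounds go, it stays open whether 3,4-difluorophenyl differs in size of number from these non-aromatic rings. The compounds shown also leave open whether an amine, a carboxylic acid or a longer chain at this place would stand level with them.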